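This account rests on a few compounds, and the source may have more. Where it says the series, first, only, none or still open, it means among the compounds named here.

Compound 1 `CNC(=O)CC[C@H](NS(=O)(=O)c1ccc([N+](=O)[O-])cc1)C(=O)O`, compound 2 `CC(C)NC(=O)CC[C@H](NS(=O)(=O)c1ccc([N+](=O)[O-])cc1)C(=O)O` and compound 3 `CC(C)CNC(=O)CC[C@H](NS(=O)(=O)c1ccc([N+](=O)[O-])cc1)C(=O)O` share one core and differ only in the group on an amide-type nitrogen. All three belong to a functional assay on K562 cells (Homo sapiens) for cytotoxicity, read by MTT assay, with a stated time of 48 h (on this read-out higher numbers stand for weaker inhibition and lower numbers for stronger inhibition), where two results are known so far. Compound 1 gives > 500000 nM, and this is a limit of the assay, not a number. For the measured compounds named here, compound 2 gives 19800 nM, the only true number available in this assay.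

The next change puts isobutyl in place of isopropyl on the amide-type nitrogen (isobutyl in place of isopropyl on an amide-type nitrogen). Going by the values given here, one measured step bears on it, because an at least 25-fold lower number from compound 1 to compound 2 (1.40 log units; beyond the scatter) came from isopropyl replacing methyl on that same nitrogen. That step was large and lay beyond the scatter, but it is a single step, so it gives a direction rather than a trend. Swapping isopropyl for isobutyl is a smaller alteration, so only a small further fall in the number is expected in this assay, possibly no more than the scatter. The expected change is a 1.5-fold lower number from compound 2 to compound 3 (0.18 log units; within the scatter). For compound 3 the estimated value is 13000 nM, with an expected range of 4000 nM to 45000 nM.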

Compound 3, half-maximal inhibitory concentration: 42500 nM
For compound 3 the middle estimate is 3.3-fold (0.51 log units) below the measured one; measured number inside the range.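

Moving from isopropyl to isobutyl on the amide-type nitrogen in this assay gives a 2.1-fold higher number from compound 2 to compound 3 (0.33 log units; beyond the scatter), so the number does not keep falling as this group gains carbons, and the single earlier step could not have shown this. The isobutyl group nevertheless remains far from methyl, with an at least 11-fold lower number from compound 1 to compound 3 (1.07 log units; beyond the scatter), so both larger groups shown give true numbers, whereas the methyl compound does not. The size of that step is only a lower bound, because compound 1 stands at a limit and not at a number: the limit of > 500000 nM in this assay, at which 1 of the 3 values shown sits.

The compounds shown leave open how a longer straight chain such as n-butyl, a ring such as cyclohexyl or benzyl, or a chain carrying an amine or a carboxylic acid would read on this nitrogen in this assay. For the compounds shown here, with compound 2 and compound 3 as the only true numbers, it also remains open whether the rise at isobutyl marks a real turning point or a local step that further groups on the same nitrogen would reverse.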